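The compounds below may be only part of what the source reports. "The series", "measured", "known", "first", "only" and "open" are said of these compounds alone.

Compound 3 `CC(=O)Nc1ccc(C(=O)C[C@@H](O)[C@H](C)C[C@@H](C)[C@H](O)[C@H](C)/C=C/C=C/C=C/[C@H](O)CC(=O)O)cc1` belongs to a small set of close analogues that share one core and were tested in a functional assay on SK-HEP1 cells (Homo sapiens) for cytotoxicity, read by sulforhodamine B assay, with a stated time of 72 h; on this read-out lower numbers stand for stronger inhibition and higher numbers for weaker inhibition. In this assay compound 3 gives only a limit, > 10000 nM. Its two neighbours are compound 1 `C[C@H](/C=C/C=C/C=C/[C@H](O)CC(=O)O)[C@@H](O)[C@H](C)C[C@@H](C)[C@H](O)CC(=O)c1ccc(N)cc1` and compound 2 `CNc1ccc(C(=O)C[C@@H](O)[C@H](C)C[C@@H](C)[C@H](O)[C@H](C)/C=C/C=C/C=C/[C@H](O)CC(=O)O)cc1`. In this assay compound 1 also gives only a limit, > 10000 nM. In this assay compound 2 likewise gives only a limit, > 10000 nM. The three steps among them, a step that the two limits leave unreadable from compound 1 to compound 2, a step that the two limits leave unreadable from compound 1 to compound 3 and a step that the two limits leave unreadable from compound 2 to compound 3, therefore cannot be read, since every value sits at the limit of > 10000 nM in this assay, at which 3 of the 3 values shown sit. On the numbers shown, compound 3 stands no differently from the other two.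

Compound 4 `C[C@H](/C=C/C=C/C=C/[C@H](O)CC(=O)O)[C@@H](O)[C@H](C)C[C@@H](C)[C@H](O)CC(=O)c1ccc(N[C@@H]2O[C@H](CO)[C@@H](O)[C@H](O)[C@H]2O)cc1` differs from compound 3 at the nitrogen on the aromatic ring: 3,4,5-trihydroxy-6-(hydroxymethyl)oxan-2-yl in place of acetyl on a nitrogen on an aromatic ring. All three measured steps bear on changes at that same nitrogen, yet none of them has a readable size, so they offer no direction for this assay. The step expected from this change is a step that the limit leaves unreadable from compound 3 to compound 4, and the most likely outcome is once more a limit rather than a number. Compound 4 is accordingly estimated at 15000 nM in this assay, with a range from 5000 nM to 50000 nM.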

Compound 4, half-maximal inhibitory concentration: > 10000 nM
Compound 4: a limit, no number (the forecaster's own chance of this, stated with the estimate: 85%); the middle value does not contradict the limit.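

None of the steps from compound 1, compound 2 or compound 3 to compound 4 can be read in this assay, since each joins two limits rather than two numbers: (the limit of > 10000 nM in this assay, at which 4 of the 4 values shown sit). The compounds shown leave open whether any change at the nitrogen on the aromatic ring alters the result in this assay, since none of the four gives a number.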